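Step from 3-methoxyphenyl to 3,4-dimethoxyphenyl

The compounds below may be only part of what the source reports. "The series", "measured", "known", "first", "only" and "open" are said of these compounds alone.

Measured in an ADME assay on HEK293 cells (Homo sapiens) for cytotoxicity, read by MTT assay, with a stated time of 48 h; a higher number here means a weaker inhibitor, a lower number a stronger inhibitor:
- compound 1 `COc1ccc(-c2nc(C)c(C(=O)CSc3nc(-c4ccc(OC)cc4)c(C#N)c(=O)[nH]3)s2)cc1`: "not determined" (no result reported)
- compound 2 `COc1ccc(-c2nc(C)c(C(=O)CSc3nc(-c4cccc(OC)c4)c(C#N)c(=O)[nH]3)s2)cc1`: 95400 nM

In this assay compound 2 gives 95400 nM. Among the measured compounds shown here, this is the only number available for the series, so compound 2 cannot be ranked against anything. Compound 1 stands at "not determined" (no result reported) and offers no comparison.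

The next compound to be tested is compound 3 `COc1ccc(-c2nc(C)c(C(=O)CSc3nc(-c4ccc(OC)c(OC)c4)c(C#N)c(=O)[nH]3)s2)cc1`. It differs from compound 2 as follows: methoxy in place of hydrogen on an aromatic carbon. This is a methoxy in place of hydrogen on an aromatic carbon, ortho to a methoxy group and para to a large group, taking 3-methoxyphenyl to 3,4-dimethoxyphenyl. The rest of the structure is unchanged.

For the measured compounds named here, the series contains no measured step between two compounds, so nothing shows how strongly a change of this kind moves the read-out. With no evidence for either direction, the expectation is a change no larger than the usual scatter. The expected step is a 1.1-fold lower number from compound 2 to compound 3 (0.05 log units; within the scatter), which is an estimate and not a trend.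

Compound 3 is estimated at 85000 nM, with an expected range of 35000 nM to 190000 nM.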

Compound 3, half-maximal inhibitory concentration: 23300 nM
For compound 3 the middle estimate is 3.6-fold (0.56 log units) above the measured one, and the stated range ends above it.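

In this assay, methoxy in place of hydrogen on the aromatic carbon ortho to a methoxy group and para to a large group goes with a 4.1-fold lower number from compound 2 to compound 3 (0.61 log units; beyond the scatter). Among the compounds shown here, this is the first measured step, and it shows that the read-out responds to this position: taking 3-methoxyphenyl to 3,4-dimethoxyphenyl, with the rest of the structure unchanged, moves the number beyond the scatter, towards a stronger inhibitor, though the step is modest in size. Nothing measured on these compounds accounts for the step, so it stands as an observation without an explanation.

Going by these compounds, compound 1 stands at "not determined" (no result reported), so any step involving it cannot be read, and whether a single methoxy at its different place on the phenyl ring would match either neighbour remains unknown. Also open, on these data alone, is whether the same position tolerates other groups: a hydroxyl, a chlorine, an amine or a longer alkoxy chain in place of the added methoxy could move the number the same way, further, or not at all.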